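The source may report more compounds than this note shows. Statements on the series, on what has been measured and on what is new or still open speak of the compounds shown alone.

Measured compounds in an assay on HL-60 cells for agonist activity at vitamin D3 receptor (Homo sapiens), read by microscopy, with a stated time of 96 h; on this read-out lower numbers stand for an effect already at smaller amounts and higher numbers for an effect only at larger amounts of compound: compound 1 `CCOC(=O)CN(C)C(=O)c1ccc(C(CC)(CC)c2ccc(OCC(O)C(C)(C)C)c(C)c2)n1CC` gives 210 nM; compound 2 `CCn1c(C(=O)NCC(OC)OC)ccc1C(CC)(CC)c1ccc(OCC(O)C(C)(C)C)c(C)c1` gives 150 nM. Compound 3 `CCn1c(C(=O)Nc2ccc(OC(F)(F)F)cc2)ccc1C(CC)(CC)c1ccc(OCC(O)C(C)(C)C)c(C)c1` gives no number but only a limit of the assay, > 50000 nM.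

Compound 3 therefore stands at the limit of > 50000 nM in this assay, at which 1 of the 3 values shown sits, the only one of the three to do so. Compound 4 `CCn1c(C(=O)Oc2ccc(CCO)cc2)ccc1C(CC)(CC)c1ccc(OCC(O)C(C)(C)C)c(C)c1` differs from compound 3 in one place: a group of 10 heavy atoms (8 carbon, 2 oxygen; one six-membered aromatic ring of carbon only) in place of a group of 12 heavy atoms (7 carbon, 1 nitrogen, 1 oxygen, 3 fluorine; one six-membered aromatic ring of carbon only), on a carbonyl carbon. Going by the values given here, two measured steps bear on this position, an at least 230-fold higher number from compound 1 to compound 3 (2.37 log units; beyond the scatter) and an at least 330-fold higher number from compound 2 to compound 3 (2.52 log units; beyond the scatter), both large. Compound 4 keeps a six-membered aromatic ring at the carbonyl carbon but exchanges the rest of the group. Because compound 3 gives only a limit > 50000 nM, the direction of the change is open. The step from compound 3 to compound 4 is expected to be a moderate fall, an at least 5.0-fold lower number from compound 3 to compound 4 (0.69 log units; beyond the scatter). Compound 4 is estimated at 10000 nM in this assay, within 1000 nM to 50000 nM.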

Compound 4, half-maximal effective concentration: 5100 nM
Compound 4: the middle estimate sits 2.0-fold (0.29 log units) above what was measured; the measured number falls inside the stated range.
By their numbers in this assay, from the lowest: compounds 2 and 1 (each within the scatter of the next); then compound 4. At a limit, above all of these: compound 3.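

In this assay, a group with a six-membered aromatic ring on this carbonyl carbon need not leave a compound at the limit, as the step shows: an at least 9.8-fold lower number from compound 3 to compound 4 (0.99 log units; beyond the scatter). Compound 3 gives only a limit of the assay, so the full size of that step cannot be read: the limit of > 50000 nM in this assay, at which 1 of the 4 values shown sits. The ring-bearing group of compound 4 still gives a much higher number than either ring-free group, with a 34-fold higher number from compound 2 to compound 4 (1.53 log units; beyond the scatter) and a 24-fold higher number from compound 1 to compound 4 (1.39 log units; beyond the scatter).

The compounds shown leave open which part of the entering group accounts for the change. They also leave open whether a carboxylic acid or an unsubstituted phenoxy group on this carbonyl carbon would come closer to the ring-free groups.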